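The source may report more compounds than this note shows. Statements on the series, on what has been measured and on what is new or still open speak of the compounds shown alone.

Working notes on a short series read in a functional assay on NCI-H1299 cells (Homo sapiens) for inhibition, read by CCK-8 assay, with a stated time of 72 h, tested at 1 uM; on this read-out lower numbers stand for a weaker effect and higher numbers for a stronger effect at the one concentration tested. Compound 1 `CN(C)C(=O)c1cc2cnc(Nc3ccc(S(=O)(=O)NCCCCCN=C=S)cc3)nc2n1C1CCCC1` gives 52.1% in this assay. Compound 2 `CN(C)C(=O)c1cc2cnc(Nc3ccc(S(=O)(=O)NCCCCCCN=C=S)cc3)nc2n1C1CCCC1` differs from compound 1 by a group of 4 heavy atoms (2 carbon, 1 nitrogen, 1 sulfur; no ring) in place of a group of 3 heavy atoms (1 carbon, 1 nitrogen, 1 sulfur; no ring), on a saturated chain carbon, five bonds along the chain from a sulfonamide nitrogen. In this assay compound 2 gives 42.4%; the step is a number 9.7 percentage points lower from compound 1 to compound 2 (within the scatter). Compound 3 `CN(C)C(=O)c1cc2cnc(Nc3ccc(C(=O)NCCCCCCN=C=S)cc3)nc2n1C1CCCC1` carries a different core: a group of 12 heavy atoms (8 carbon, 2 nitrogen, 1 oxygen, 1 sulfur; no ring) in place of a group of 12 heavy atoms (6 carbon, 2 nitrogen, 2 oxygen, 2 sulfur; no ring), on an aromatic carbon. In this assay compound 3 gives 49.4%, and the step is a number 2.7 percentage points lower from compound 1 to compound 3 (within the scatter). Compound 4 `CN(C)C(=O)c1cc2cnc(Nc3ccc(C(=O)NCCCCCCCN=C=S)cc3)nc2n1C1CCCC1` has not yet been measured and differs from compound 3 by a group of 4 heavy atoms (2 carbon, 1 nitrogen, 1 sulfur; no ring) in place of a group of 3 heavy atoms (1 carbon, 1 nitrogen, 1 sulfur; no ring), on a saturated chain carbon, six bonds along the chain from an amide-type nitrogen. This is the same kind of change as that from compound 1 to compound 2, but not the same change: the earlier one sits five bonds along the chain from a sulfonamide nitrogen, the new one six bonds along the chain from an amide-type nitrogen. Among the measured compounds shown here, the expected step for compound 4 is a number 7.4 percentage points lower from compound 3 to compound 4 (within the scatter), set beside the measured one because a number 9.7 percentage points lower from compound 1 to compound 2 (within the scatter) is the only guide available for this kind of change, and it lay within the scatter. Compound 4 is therefore estimated at 42% in this assay, with the expected range running from 30% to 54%.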

Compound 4, a percentage reported as inhibition, at one concentration (the size of the read-out at that concentration, not a potency): 75.7%
Compound 4: middle estimate off by 33.7 percentage points, on the low side, outside the stated range (above it).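

In this assay, the group of 4 heavy atoms in place of the group of 3 heavy atoms gives a number 26.3 percentage points higher from compound 3 to compound 4 (beyond the scatter), and this step does not match the earlier one on the core of compound 1: the same change on two cores in this assay, a number 9.7 percentage points lower (within the scatter) from compound 1 to compound 2 and a number 26.3 percentage points higher (beyond the scatter) from compound 3 to compound 4, 36 percentage points apart, beyond the scatter of two such steps

In this series, then, the step measured on one core is no reliable guide to the step on the other, and the change cannot be treated as carrying over with a fixed size or direction. This rests on a single pair per core, each read at one concentration, and it shows neither why the steps part nor whether the gap follows the sulfonamide or amide-type nitrogen or the different place along the chain.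

The compounds shown leave open whether a longer chain on the core of compound 4 would hold, raise or lower the read-out, and what the same longer chain would do on the core of compound 1. They also leave open whether the effect survives with an amine at the chain end in place of the group of 4 heavy atoms.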